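This account rests on a few compounds, and the source may have more. Where it says the series, first, only, none or still open, it means among the compounds named here.

In a functional assay on the whole organism (strain Wistar) for inhibition, with Rattus norvegicus as the target, read by paw edema, with stated times of 60 min and 1 h, at a dose of 100 mg/kg by the oral route (a higher number here means more inhibition at the dose given (going by the name of the read-out), a lower number less inhibition), three amides sharing one core have been measured. Compound 1 `CCN(CC)C(=O)CC1CCc2cc(OC)c(OC)cc21` gives 31.3%. Compound 2 `CCCNC(=O)CC1CCc2cc(OC)c(OC)cc21` gives 18.8%. Compound 3 `CCCCCNC(=O)CC1CCc2cc(OC)c(OC)cc21` gives 34.4%, the highest of the three numbers, though its gap to compound 1 lies within the scatter; only compound 2 sits clearly lower, as shown by a number 15.6 percentage points higher from compound 2 to compound 3 (beyond the scatter).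

Compound 4 `COc1cc2c(cc1OC)C(CC(=O)N1CCOCC1)CC2` has not been measured. It differs from compound 3 in one place: morpholin-4-yl in place of pentylamino on a carbonyl carbon. Among the compounds with values here, the steps that bear on this are the exchanges of the amine on the carbonyl carbon: a number 12.5 percentage points lower from compound 1 to compound 2 (beyond the scatter) and a number 3.1 percentage points higher from compound 1 to compound 3 (within the scatter). Replacing a dialkylamino with a secondary alkylamino moved the number modestly in one case and not beyond the scatter in the other, so the amine portion has so far shifted the read-out only modestly. Compound 4 is therefore expected to stay close to compound 3, with an expected step of a number 6.4 percentage points lower from compound 3 to compound 4 (within the scatter). The estimate for compound 4 is 28%, within a range from 12% to 42%.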

Compound 4, a percentage reported as inhibition, in the whole organism at one dose (the size of the read-out at that dose, not a potency): 15.6%
Estimate against measurement, compound 4: 12.4 percentage points above; the range from low to high includes it.
By their numbers in this assay, from the lowest: compounds 4 and 2 (each within the scatter of the next); then compounds 1 and 3 (each within the scatter of the next).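

Within the data shown here, on the carbonyl carbon, morpholin-4-yl brings a ring into the amine part for the first time, and in this assay it gives a number 18.8 percentage points lower from compound 3 to compound 4 (beyond the scatter) and also a number 15.7 percentage points lower from compound 1 to compound 4 (beyond the scatter), so this ring does not hold the number at the level of the pentylamino and diethylamino amides. Against the propylamino amide the same exchange gives a number 3.2 percentage points lower from compound 2 to compound 4 (within the scatter), which places compound 4 level with compound 2 even though morpholin-4-yl lacks the amide hydrogen that propylamino keeps. What lies behind these steps is not explained by any data available here.

From the compounds shown here alone, whether the ring or its oxygen sets the number stays open, and a piperidin-1-yl amide on the same carbonyl carbon would separate the two. Also open, going by these compounds, is whether a longer chain, such as heptylamino, would follow pentylamino or fall away.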